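This account rests on a few compounds, and the source may have more. Where it says the series, first, only, none or still open, it means among the compounds named here.

Three related compounds have been tested in a functional assay on HeLa cells (Homo sapiens) for inhibition, read by MTT assay, with a stated time of 72 h, tested at 10 ug/mL; a higher number here means more inhibition of growth at the concentration tested, a lower number less inhibition of growth. In this test compound 1 `C=C1[C@H](OCC(C)C)C[C@@H](OC(=O)c2cccnc2)C(C)(C)/C=C/[C@@H](C)C(=O)[C@@]2(OC(C)=O)C[C@H](C)[C@H](OC(C)=O)[C@@H]2[C@H]1OC(C)=O` gives 18.3%, compound 2 `C=C1[C@H](OC(C)=O)C[C@@H](OC(C)=O)C(C)(C)/C=C/[C@@H](C)C(=O)[C@@]2(OC(C)=O)C[C@@](C)(OC(C)=O)[C@H](OC(C)=O)[C@@H]2[C@H]1OC(C)=O` gives 11.4%, and compound 3 `CC(=O)O[C@H]1[C@H]2OC(=O)CC[C@](O)([C@@H]1OCC(C)C)[C@H](OC(C)=O)[C@H]1[C@@H](OC(C)=O)[C@](C)(OC(C)=O)C[C@]1(OC(C)=O)C(=O)[C@H](C)[C@H]1O[C@@H]1C2(C)C` gives 5.3%. The number for compound 2 lies within the usual scatter of the numbers for both of the other compounds, so its place among them is not firmly settled.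

Compound 4 `C=C1[C@H](OC(C)=O)C[C@@H](OC(=O)c2cccnc2)C(C)(C)/C=C/[C@@H](C)C(=O)[C@@]2(OC(C)=O)C[C@@](C)(OC(C)=O)[C@H](OC(C)=O)[C@@H]2[C@H]1OC(C)=O` departs from compound 2 by a single change: pyridin-3-yl in place of methyl on a carbonyl carbon. Here pyridin-3-yl stands in place of methyl on a carbonyl carbon, which turns an acetoxy group into ((pyridin-3-yl)carbonyl)oxy. Among the compounds with values here, no measured pair shows this change alone. Within the data shown here, the only hint comes from compound 1, which also carries ((pyridin-3-yl)carbonyl)oxy and gives 18.3%, but it differs from compound 2 elsewhere as well.

A small upward step is therefore expected in this assay, one not beyond the scatter. The estimated change is a number 3.6 percentage points higher from compound 2 to compound 4 (within the scatter). For compound 4 the expected value is 15%, with an estimated range from 4% to 30%.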

Compound 4, percent growth inhibition at one concentration: 13.9%
Beside the measured number, compound 4's estimate is 1.1 percentage points above it; low and high end bracket the measured number.
By their numbers in this assay, from the lowest: compounds 3, 2, 4 and 1 (each within the scatter of the next, the first and the last beyond it).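

Read alone in this assay, pyridin-3-yl in place of methyl on a carbonyl carbon gives a number 2.5 percentage points higher from compound 2 to compound 4 (within the scatter), the first direct reading of this change. At this position, the larger ((pyridin-3-yl)carbonyl)oxy group can therefore stand in place of acetoxy with no difference from compound 2 that can be told from the scatter, and compound 4 gives 13.9% at the single concentration tested. Nothing available explains this result or bears on what the new ring does here.

As far as these compounds go, it remains open whether a benzoyl group, a hexanoyl chain or an ester carrying an amine at this position would read differently from acetoxy. From the compounds shown here alone, it also remains open whether the same change would give a similar step on the core of compound 1 or compound 3.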